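Solubility from compound 3 to compound 4

A few compounds are considered here, and "the series" means these few. Any claim that something is new, unique, unknown or untested is made for them only; others in the source may bear on it.

Measured in a physicochemical assay for solubility, in phosphate buffer, measured as kinetic solubility, at pH 7.4; a lower number here means a less soluble compound, a higher number a more soluble compound:
- compound 1 `Cc1ccccc1-c1nc(CN2CCC(C(=O)NCCCN3CCCCC3)CC2)c(C)o1` gives > 65 ug/mL as a limit
- compound 2 `Cc1ccccc1-c1nc(CN2CCC(C(=O)NCCCN3[C@H](C)CCC[C@@H]3C)CC2)c(C)o1` gives > 69 ug/mL as a limit
- compound 3 `Cc1ccccc1-c1nc(CN2CCC(C(=O)NCCN3C[C@H](C)C[C@H](C)C3)CC2)c(C)o1` gives > 67 ug/mL as a limit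

Compound 3 therefore has no exact number, only the limit > 67 ug/mL in this assay. Compound 4 `CCCN(CCC)CCNC(=O)C1CCN(Cc2nc(-c3ccccc3C)oc2C)CC1` carries dipropylamino in place of 3,5-dimethylpiperidin-1-yl on a saturated chain carbon, two bonds along the chain from an amide-type nitrogen, as counted in dipropylamino in place of 3,5-dimethylpiperidin-1-yl on a saturated chain carbon, two bonds along the chain from an amide-type nitrogen here. The measured steps that bear on it are a step that the two limits leave unreadable from compound 1 to compound 3 and a step that the two limits leave unreadable from compound 2 to compound 3 and also a step that the two limits leave unreadable from compound 1 to compound 2, so none gives a size. The expected change is an at least 1.0-fold lower number from compound 3 to compound 4 (0.00 log units; that floor lies within the scatter) and no larger than the usual scatter. For compound 4 the estimated value is 66 ug/mL with an expected range from 48 ug/mL to 72 ug/mL in this assay.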

Compound 4, solubility: > 65 ug/mL
Compound 4: a limit, no number; the forecaster's own chance of this, stated with the estimate: 85%; the middle value does not contradict the limit.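

In this assay compound 4 gives > 65 ug/mL, which is a limit. Going by these compounds alone, no step to compound 4 from compound 1, compound 2 or compound 3 can be read. Whether the solubility of these compounds differs at all remains open.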